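This account rests on a few compounds, and the source may have more. Where it says the series, first, only, none or still open, it means among the compounds named here.

The measured compounds in an assay on isolated protein for inhibition of NEDD8-activating enzyme E1 regulatory subunit (Homo sapiens), read by Western blot, with stated times of 10 min and 30 min, tested at 25 uM; a higher number here means more inhibition at the concentration tested (going by the name of the read-out), a lower number less inhibition:

- compound 1, `CCOc1nc2cccc(C(=O)NCCCN(C)C)c2n1Cc1ccc(-c2ccccc2-c2nnn[nH]2)cc1`, gives 29.5%
- compound 2, `CCOC(=O)CNC(=O)c1cccc2nc(OCC)n(Cc3ccc(-c4ccccc4-c4nnn[nH]4)cc3)c12`, gives 46.5%
- compound 3, `CCOc1nc2cccc(C(=O)Nc3ccccc3)c2n1Cc1ccc(-c2ccccc2-c2nnn[nH]2)cc1`, gives 34.6%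

Compound 3 stands second highest of these three numbers. Its nearest neighbour is compound 1, and the step of a number 5.1 percentage points higher from compound 1 to compound 3 (within the scatter) lies within the scatter. Compound 2 is further away: the step of a number 11.9 percentage points lower from compound 2 to compound 3 (beyond the scatter) is modest but beyond the scatter.

Compound 4, `CCOc1nc2cccc(C(=O)Nc3ccncc3)c2n1Cc1ccc(-c2ccccc2-c2nnn[nH]2)cc1`, differs from compound 3 in one place: pyridin-4-yl in place of phenyl on an amide-type nitrogen. Among the compounds with values here, none of the measured steps exchanges phenyl for pyridin-4-yl. The steps that come closest alter what hangs on the amide-type nitrogen or its attached chain, and they range from a number 5.1 percentage points higher from compound 1 to compound 3 (within the scatter) to a number 17 percentage points higher from compound 1 to compound 2 (beyond the scatter), so changes in this region have shifted the read-out only modestly at most. Here the ring keeps its size and only one ring atom changes, so the expected step in this assay is a number 2.4 percentage points higher from compound 3 to compound 4 (within the scatter), none beyond the scatter.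

Compound 4 is therefore estimated at 37%, expected to fall between 22% and 52%.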

Compound 4, a percentage reported as inhibition, at one concentration (the size of the read-out at that concentration, not a potency): 39.8%
Estimate against measurement, compound 4: 2.8 percentage points below; measured number inside the range.
By their numbers in this assay, from the lowest: compounds 1, 3, 4 and 2 (each within the scatter of the next, the first and the last beyond it).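

In this assay, putting pyridin-4-yl in place of phenyl on the amide-type nitrogen adds one ring nitrogen and one hydrogen-bond acceptor, and the result is a number 5.2 percentage points higher from compound 3 to compound 4 (within the scatter), so this position accepts the exchange with no readable change. Other comparisons shift only slightly: there is a number 6.7 percentage points lower from compound 2 to compound 4 (within the scatter), whereas compound 2 and compound 3 lie further apart, and there is a number 10.3 percentage points higher from compound 1 to compound 4 (beyond the scatter), whereas compound 1 and compound 3 lie within the scatter, but with the direct step so small, these shifts carry little weight. No measurement here offers an explanation for these numbers.

The compounds shown leave open whether the place of the ring nitrogen matters, which pyridin-3-yl or pyridin-2-yl would test. As far as these compounds go, it also remains open how a carboxylic acid in place of the ethyl ester of compound 2 would read.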